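Fluorine Moved Around the Ring: Compound 1 to Compound 4

This account rests on a few compounds, and the source may have more. Where it says the series, first, only, none or still open, it means among the compounds named here.

Measured compounds:
- Compound 1, `Fc1ccccc1Cn1cc(CSC(=S)N2CCNCC2)nn1`: 19400 nM
- Compound 2, `COc1cc(Cn2cc(CSC(=S)N3CCNCC3)nn2)cc(OC)c1OC`: "not determined" (no result reported)
- Compound 3, `CC(C)(C)OC(=O)N1CCN(C(=S)SCc2cn(Cc3cc(=O)oc4cc(O)ccc34)nn2)CC1`: 4960 nM

The read-out throughout is a functional assay on MGC-803 cells (Homo sapiens) for inhibition, read by MTT assay, with a stated time of 72 h; on this read-out higher numbers stand for weaker inhibition and lower numbers for stronger inhibition. Compound 2 has no result in this assay. Among the two compounds with a number, compound 1 stands highest, which on this read-out means the weaker of the two; compound 3 gives the lower number, and the gap between compound 1 and compound 3 is wider than the scatter of repeated measurements. Within the data shown here, no pair of compounds measured here differs in only one place, so no single step can be read off directly.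

Compound 4, `Fc1ccc(Cn2cc(CSC(=S)N3CCNCC3)nn2)cc1`, has not yet been tested. It differs from compound 1 in one respect: 4-fluorophenyl in place of 2-fluorophenyl on a saturated chain carbon bound to an aromatic nitrogen. The two compounds contain the same atoms, joined differently. Nothing measured here shows what moving the fluorine from one position of the phenyl ring to another does in this assay, so the expectation rests on the absence of any other change. The step from compound 1 to compound 4 is expected to be a 1.2-fold lower number from compound 1 to compound 4 (0.08 log units; within the scatter), that is, no change beyond the scatter. Compound 4 is therefore estimated at 16000 nM, within a range of 6000 nM to 45000 nM.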

Compound 4, half-maximal inhibitory concentration: 32500 nM
Beside the measured number, compound 4's estimate is 2.0-fold (0.31 log units) below it; measured number inside the range.
By their numbers in this assay, from the lowest: compound 3; then compounds 1 and 4 (each within the scatter of the next).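

In this assay, among these compounds, the change to 4-fluorophenyl in place of 2-fluorophenyl on a saturated chain carbon bound to an aromatic nitrogen gives a 1.7-fold higher number from compound 1 to compound 4 (0.22 log units; within the scatter) and is the first step here that can be read between two compounds differing in one place. The two compounds contain the same atoms, so this step concerns only where the fluorine sits on the phenyl ring, and for these two placements the difference does not exceed what repeated measurements of the same compound could produce. No accompanying measurement bears on this result, so the data offer no explanation for it.

As far as these compounds go, whether another group on the phenyl ring, such as a chlorine atom or a nitrile, or a phenyl ring with no added group at all, would give a number clearly apart from those of compound 1 and compound 4 remains open. Compound 3 differs from compound 1 in more than one place, so its number cannot show which of its changes matters, and a single change to the piperazine-bearing end of the shared core, such as an added methyl group, would be needed to examine that part alone.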